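A Piperidine Gives Way to a Butylsulfanyl Chain

The compounds below may be only part of what the source reports. "The series", "measured", "known", "first", "only" and "open" are said of these compounds alone.

Compound 1 `CC(C(=O)NCc1ccc(C(F)(F)F)cc1N1CCC(C(F)(F)F)CC1)c1ccc(NS(C)(=O)=O)c(F)c1` was measured in an assay on CHO cells for antagonist activity at transient receptor potential cation channel subfamily V member 1 (Homo sapiens), read by FLIPR (a higher number here means a weaker inhibitor, a lower number a stronger inhibitor), and gave 0.4 nM. Among the measured compounds, compound 1 stands level with compound 3 `CC(C(=O)NCc1ccc(C(F)(F)F)cc1N1CCC(Cc2ccc(F)cc2)CC1)c1ccc(NS(C)(=O)=O)c(F)c1`, which gives 0.4 nM in this assay; together they hold the lowest numbers, while compound 2 `CC(C(=O)NCc1ccc(C(F)(F)F)cc1N1CCC(Cc2ccccc2)CC1)c1ccc(NS(C)(=O)=O)c(F)c1` gives 1.4 nM. The measured steps all vary the group on the saturated ring: a 3.5-fold higher number from compound 1 to compound 2 (0.54 log units; beyond the scatter), no change at the digits printed from compound 1 to compound 3 (within the scatter) and a 3.5-fold lower number from compound 2 to compound 3 (0.54 log units; beyond the scatter). Compound 4 `CCCCSc1cc(C(F)(F)F)ccc1CNC(=O)C(C)c1ccc(NS(C)(=O)=O)c(F)c1` has not yet been measured in this assay. It differs from compound 1 in one place: butylsulfanyl in place of 4-(trifluoromethyl)piperidin-1-yl on an aromatic carbon. Among the compounds with values here, no measured step bears directly on this change; the saturated ring itself was kept in every measured compound, and the measured steps show only that changes of its substituent move the number by modest amounts. For compound 4 a higher number than for compound 1 is therefore expected, with wide uncertainty, the step of a 7.5-fold higher number from compound 1 to compound 4 (0.88 log units; beyond the scatter) being the estimate. The expected value for compound 4 is 3 nM, within a range from 0.5 nM to 20 nM.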

Compound 4, inhibition constant: 1.9 nM
For compound 4 the middle estimate is 1.6-fold (0.20 log units) above the measured one; the range from low to high includes it.
By their numbers in this assay, from the lowest: compounds 1 and 3 (each within the scatter of the next); then compounds 2 and 4 (each within the scatter of the next).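

The position that carries the piperidine in compound 1 does not need a saturated ring to stay potent: in this assay compound 4 gives 1.9 nM with an open butylsulfanyl chain, which has no ring. The exchange does carry a modest cost, a 4.8-fold higher number from compound 1 to compound 4 (0.68 log units; beyond the scatter) and so beyond the scatter, but the number stays in the low nanomolar range. Nothing shown explains this step or separates the loss of the ring from the loss of the trifluoromethyl group.

Going by these compounds, it remains open whether a shorter ethylsulfanyl chain, a butoxy chain with oxygen in place of sulfur, or a plain pentyl chain would hold the number as well. Also open, on these data alone, is whether a trifluoromethyl group at the end of the butylsulfanyl chain would bring it back towards that of compound 1.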